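Swapping thiophene for 2-hydroxyphenyl in compound 4

The source may report more compounds than this note shows. Statements on the series, on what has been measured and on what is new or still open speak of the compounds shown alone.

Measured in a functional assay on G-361 cells (Homo sapiens) for inhibition, with a stated time of 72 h; a lower number here means a stronger inhibitor, a higher number a weaker inhibitor:
- Compound 1 `NC1CCC(Nc2nc(NCc3ccc(-c4ccco4)cc3)c3ncn(C4CCCC4)c3n2)CC1` gives 164 nM
- Compound 2 `NC1CCC(Nc2nc(NCc3ccc(-c4cccc(F)c4)nc3)c3ncn(C4CCCC4)c3n2)CC1` gives 49 nM
- Compound 3 `NC1CCC(Nc2nc(NCc3ccc(-c4cccs4)nc3)c3ncn(C4CCCC4)c3n2)CC1` gives 150 nM

Compound 3 sits level with compound 1, as a 1.1-fold lower number from compound 1 to compound 3 (0.04 log units; within the scatter) shows, so that step offers little guidance, and two groups differ in it. Compound 2 has the lowest number of the three, and this is the more useful comparison. The next compound, compound 4 `NC1CCC(Nc2nc(NCc3ccc(-c4ccccc4O)nc3)c3ncn(C4CCCC4)c3n2)CC1`, carries 2-hydroxyphenyl in place of thiophen-2-yl on an aromatic carbon, next to the ring nitrogen: 2-hydroxyphenyl in place of thiophen-2-yl on an aromatic carbon.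

The closest guide is a 3.1-fold higher number from compound 2 to compound 3 (0.49 log units; beyond the scatter), where thiophen-2-yl replaced 3-fluorophenyl. Compound 4 also returns to a six-membered aromatic ring of carbon only, so part of that gap may be recovered. Going by the values given here, no measured compound carries a hydroxyl group, however, so this reading rests on one pair and remains uncertain.

The expected change is modest and towards stronger inhibition, with an estimated 2.1-fold lower number from compound 3 to compound 4 (0.33 log units; beyond the scatter). For compound 4 the estimated value is 70 nM, with an expected range of 22 nM to 200 nM.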

Compound 4, half-maximal inhibitory concentration: 24 nM
Beside the measured number, compound 4's estimate is 2.9-fold (0.46 log units) above it; measured number inside the range.
By their numbers in this assay, from the lowest: compound 4; then compound 2; then compounds 3 and 1 (each within the scatter of the next).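

In this assay, going by these compounds alone, the group on this aromatic carbon, next to the ring nitrogen, moves the number further than the earlier compounds showed, with a 6.3-fold lower number from compound 3 to compound 4 (0.80 log units; beyond the scatter) when 2-hydroxyphenyl replaces thiophen-2-yl. The new group also improves on 3-fluorophenyl, the best group at this carbon until now, giving a 2.0-fold lower number from compound 2 to compound 4 (0.31 log units; beyond the scatter) even though both groups contain a six-membered aromatic ring of carbon only, so the ring type alone does not set the number. No measurement in hand explains why the hydroxyl-bearing ring gives this result.

Going by these compounds, it remains open whether the gain depends on the hydroxyl group itself or on where it sits on the ring. Plain phenyl, 2-methoxyphenyl, 2-aminophenyl and 3-hydroxyphenyl at this carbon would help separate those two possibilities.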